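Working notes: from compound 2 to compound 3

A few compounds are considered here, and "the series" means these few. Any claim that something is new, unique, unknown or untested is made for them only; others in the source may bear on it.

- compound 1 `CNc1[nH]c(=O)n(O)c(=O)c1C(=O)NCc1ccccc1`: > 24 h (a limit)
- compound 2 `CCNc1[nH]c(=O)n(O)c(=O)c1C(=O)NCc1cccc(Cl)c1F`: > 24 h (a limit)

Both entries come from a physicochemical assay for pharmacokinetics; on this read-out higher numbers stand for a longer-lived compound and lower numbers for a shorter-lived compound. Compound 2 stands at > 24 h, which is a limit and not a number. The only reference point in the series is the limit of > 24 h in this assay, at which 2 of the 2 values shown sit.

Compound 3 `CCNc1[nH]c(=O)n(O)c(=O)c1C(=O)NCc1ccc(C)c(F)c1` differs from compound 2 on a saturated chain carbon bound to an amide-type nitrogen, with 3-fluoro-4-methylphenyl in place of 3-chloro-2-fluorophenyl on a saturated chain carbon bound to an amide-type nitrogen.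

For the measured compounds named here, no step between measured compounds is available to size this change. In this assay, no step beyond the scatter is expected, in either direction, and this expectation rests on (the limit of > 24 h in this assay, at which 2 of the 2 values shown sit). The estimated change is a step that the limit leaves unreadable from compound 2 to compound 3. For compound 3 the expected half-life is 30 h, with an estimated range of 15 h to 60 h.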

Compound 3, half-life: > 24 h
Compound 3 ended at the assay's limit (the forecaster's own chance of this, stated with the estimate: 80%); the middle value lies beyond the limit too.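

In this assay compound 3 gives > 24 h which is a limit and not a number. For the compounds shown here, compound 2 also sits at a limit, so no step between compound 2 and compound 3 can be read. The compounds shown leave open how far any of their half-lives extends beyond the limit.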